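Replacing a Thioester Tail with a Nitrile Tail

The source may report more compounds than this note shows. Statements on the series, on what has been measured and on what is new or still open speak of the compounds shown alone.

Of the compounds shown here, three sharing one core have been measured in an assay for inhibition of Fatty-acid amide hydrolase 1 (Rattus norvegicus), using a Dixon plot, with a stated time of 3 h; on this read-out lower numbers stand for stronger inhibition and higher numbers for weaker inhibition. Compound 1 `O=Cc1ccc(-c2cnc(C(=O)CCCCCCc3ccccc3)o2)nc1` gives 2 nM. Compound 2 `O=C(CCCCCCc1ccccc1)c1ncc(-c2ccc(CCl)cn2)o1` gives 20.1 nM, and the step of a 10-fold higher number from compound 1 to compound 2 (1.00 log units; beyond the scatter) shows that this change, chloromethyl in place of formyl on an aromatic carbon, costs potency. Compound 3 `CSC(=O)CCCCc1cnc(C(=O)CCCCCCc2ccccc2)o1` gives 1.4 nM, the lowest of the three numbers; it sits within the scatter of compound 1 (a 1.4-fold lower number from compound 1 to compound 3 (0.15 log units; within the scatter)) but clearly apart from compound 2 (a 14-fold lower number from compound 2 to compound 3 (1.16 log units; beyond the scatter)).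

Compound 4 `N#CCCCCCc1cnc(C(=O)CCCCCCc2ccccc2)o1` differs from compound 3 in one place: cyanomethyl in place of (methylsulfanyl)carbonyl on a saturated chain carbon, four bonds along the chain from an aromatic carbon. For the measured compounds named here, no measured step changes this same position, so the expectation rests on analogy. The two steps that touch the chain region, from compound 1 to compound 3 and from compound 2 to compound 3, show that a carbonyl-bearing group at the end of the molecule goes with the lower numbers, while compound 2, which lacks one, is weakest. Compound 4 keeps a hydrogen-bond acceptor but loses the carbonyl, so a modest rise in this assay is expected, estimated as a 3.6-fold higher number from compound 3 to compound 4 (0.55 log units; beyond the scatter). Compound 4 is therefore expected to give about 5 nM, with a likely range from 1.5 nM to 20 nM.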

Compound 4, inhibition constant: 4 nM
The estimate for compound 4 lay 1.3-fold (0.10 log units) above the measured number; measured number inside the range.
By their numbers in this assay, from the lowest: compounds 3, 1 and 4 (each within the scatter of the next, the first and the last beyond it); then compound 2.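

In this assay, the (methylsulfanyl)carbonyl at the end of the chain can give way to cyanomethyl at only a modest cost (a 2.9-fold higher number from compound 3 to compound 4 (0.46 log units; beyond the scatter)), so this position keeps a low number without that carbonyl. Compound 4 also stands within the scatter of the formyl-bearing compound 1 (a 2.0-fold higher number from compound 1 to compound 4 (0.30 log units; within the scatter)) and clearly apart from the chloromethyl-bearing compound 2 (a 5.0-fold lower number from compound 2 to compound 4 (0.70 log units; beyond the scatter)). Compound 4 therefore goes against the earlier impression that low numbers belong to compounds with a carbonyl-bearing end group, although no measurement here explains the difference between the two chain ends.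

The change swaps the whole end group at once, so the compounds shown cannot separate the loss of the carbonyl from the loss of the sulfur, a question that a methyl ester at this chain end would address. From the compounds shown here alone, how a carboxylic acid, an amide or an amine would fare at this position also remains open, as does the effect of a longer chain carrying the nitrile.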